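Semicarbazone series: one cytotoxicity value, one sulfur exchange

A few compounds are considered here, and "the series" means these few. Any claim that something is new, unique, unknown or untested is made for them only; others in the source may bear on it.

Measured compounds, as read in an ADME assay on MT4 cells (Homo sapiens) for cytotoxicity, read by MTT assay, with a stated time of 96 h; a higher number here means that more compound is tolerated, a lower number that less compound is tolerated
compound 1 `COc1ccc(-c2nc3cc(/C(C)=N/NC(N)=O)ccc3n2C2CCCCC2)c(OC)c1` gives 23000 nM
compound 2 `C/C(=N\NC(N)=O)c1ccc2c(c1)nc(-c1ccccn1)n2C1CCCCC1` is recorded as "not determined" (no result reported)

Within the data shown here, compound 1 holds the only number available, so it cannot be ranked against anything, and compound 2 offers no comparison. The next compound to be read is compound 3 `COc1ccc(-c2nc3cc(/C(C)=N/NC(N)=S)ccc3n2C2CCCCC2)c(OC)c1`, which keeps the core of compound 1 and changes one group, on an amine nitrogen (a group of 3 heavy atoms (1 carbon, 1 nitrogen, 1 sulfur; no ring) in place of a group of 3 heavy atoms (1 carbon, 1 nitrogen, 1 oxygen; no ring), on an amine nitrogen). Among the measured compounds shown here, no measured step shows what this exchange does, so the expectation rests on the structural change and on compound 1 at 23000 nM as the starting point. A modest move towards a lower number in this assay is expected, perhaps only just beyond the usual scatter. The expected move is a 2.3-fold lower number from compound 1 to compound 3 (0.36 log units; beyond the scatter) in this estimate. For compound 3 the estimated value is 10000 nM (range 3000 nM to 30000 nM) in this assay.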

Compound 3, half-maximal cytotoxic concentration: 17000 nM
For compound 3 the middle estimate is 1.7-fold (0.23 log units) below the measured one; the range from low to high includes it.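

In this assay, replacing carbamoyl on an amine nitrogen with the group carrying sulfur in place of oxygen gives a 1.4-fold lower number from compound 1 to compound 3 (0.13 log units; within the scatter), so compound 1 and compound 3 cannot be told apart in this read-out. Among these compounds, this is the first measured exchange at this position, and it shows that, on the core of compound 1, this swap of oxygen for sulfur leaves the tolerated concentration within the usual scatter. No supporting data bear on why the two compounds read alike.

Still open, from the compounds shown here alone, is whether the same exchange would read alike on a different core. Going by these compounds, it is also open whether a larger replacement on this amine nitrogen, such as an acetyl group, a methyl group or a longer chain, would move the value beyond the scatter.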